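This account rests on a few compounds, and the source may have more. Where it says the series, first, only, none or still open, it means among the compounds named here.

In a functional assay on RS4-11 cells (Homo sapiens) for inhibition, read by CCK-8 assay, with a stated time of 48 h, tested at 20 uM (a higher number here means more inhibition of growth at the concentration tested, a lower number less inhibition of growth), compound 1 `COc1ccc(Cc2nnc(NC(=O)/C(C#N)=C/c3ccccc3OS(=O)(=O)c3ccc(C)cc3)s2)cc1` gives 70%, compound 2 `Cc1ccc(S(=O)(=O)Oc2ccccc2/C=C(\C#N)C(=O)Nc2nnc(Cc3cccc4ccccc34)s2)cc1` gives 73% and compound 3 `Cc1ccc(S(=O)(=O)Oc2ccccc2/C=C(\C#N)C(=O)Nc2nnc(Cc3ccc(F)cc3)s2)cc1` gives 72%. Compound 3 therefore cannot be told apart from the other two on these numbers. Compound 4 `Cc1ccc(S(=O)(=O)Oc2ccccc2/C=C(\C#N)C(=O)Nc2nnc(Cc3cccc(F)c3)s2)cc1` has the same atoms as compound 3, joined differently: 3-fluorophenyl in place of 4-fluorophenyl on a saturated chain carbon bound to an aromatic carbon. Going by the values given here, no measured step tests this exact change, so the evidence is indirect. Three steps replace the group on that chain carbon, and all are small: a number 3 percentage points higher from compound 1 to compound 2 (within the scatter), a number 2 percentage points higher from compound 1 to compound 3 (within the scatter) and a number 1 percentage points lower from compound 2 to compound 3 (within the scatter). With these steps as the guide, no change beyond the scatter is expected in this assay, and the expected step is a number 1 percentage points lower from compound 3 to compound 4 (within the scatter). For compound 4, the estimated value is 71%, with an expected range of 61% to 81%.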

Compound 4, percent growth inhibition at one concentration: 56%
Estimate against measurement, compound 4: 15 percentage points above; the measured number lies below the stated range.
By their numbers in this assay, from the lowest: compound 4; then compounds 1, 3 and 2 (each within the scatter of the next).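

In this assay the move from 4-fluorophenyl to 3-fluorophenyl gives a number 16 percentage points lower from compound 3 to compound 4 (beyond the scatter) and thus shows that where the fluorine sits on this ring matters, although the earlier swaps of whole groups on this chain carbon stayed within the scatter. The steps of a number 17 percentage points lower from compound 2 to compound 4 (beyond the scatter) and a number 14 percentage points lower from compound 1 to compound 4 (beyond the scatter) set compound 4 apart from the other two compounds as well. Nothing shown here explains why this isomer differs. As far as these compounds go, it remains open whether 3-chlorophenyl or 3-methoxyphenyl on the same chain carbon would behave like 3-fluorophenyl, and where 2-fluorophenyl would fall.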